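Para-substituent swaps on the sulfonyl ring: cytotoxicity notes

The compounds below may be only part of what the source reports. "The series", "measured", "known", "first", "only" and "open" are said of these compounds alone.

Measured so far:
compound 1 `O=C1/C(=C/c2ccc(F)cc2)CN(S(=O)(=O)c2ccc(C(F)(F)F)cc2)C/C1=C\c1ccc(F)cc1` — 3200 nM
compound 2 `O=C1/C(=C/c2ccc(F)cc2)CN(S(=O)(=O)c2ccc(F)cc2)C/C1=C\c1ccc(F)cc1` — 8100 nM
compound 3 `O=C1/C(=C/c2ccc(F)cc2)CN(S(=O)(=O)c2ccc(Cl)cc2)C/C1=C\c1ccc(F)cc1` — 4500 nM

In a functional assay on HepG2 cells (Homo sapiens) for cytotoxicity, read by MTT assay, with a stated time of 24 h (a lower number here means a stronger inhibitor, a higher number a weaker inhibitor), compound 3 gives 4500 nM, the second highest of the three numbers; its nearest neighbour is compound 1, the furthest compound 2, and both gaps lie within the scatter.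

Compound 4 `CC(=O)Nc1ccc(S(=O)(=O)N2C/C(=C\c3ccc(F)cc3)C(=O)/C(=C/c3ccc(F)cc3)C2)cc1` differs from compound 3 in one place: acetamido in place of chloro on an aromatic carbon.

Among the compounds with values here, no measured step involves an acetamido or any donor-bearing group; the three steps all exchange halogen for trifluoromethyl or halogen for halogen on the same aromatic carbon. Of these, a 2.5-fold higher number from compound 1 to compound 2 (0.40 log units; beyond the scatter) is the only one beyond the scatter, while a 1.4-fold higher number from compound 1 to compound 3 (0.15 log units; within the scatter) and a 1.8-fold lower number from compound 2 to compound 3 (0.26 log units; within the scatter) stay inside it. Within this narrow set the para group on the sulfonyl ring moves the number only little, so for compound 4 the step is expected to be a 1.3-fold higher number from compound 3 to compound 4 (0.12 log units; within the scatter), with the direction left open by the data.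

Compound 4 is therefore estimated at 6000 nM, with a range from 2500 nM to 15000 nM.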

Compound 4, half-maximal inhibitory concentration: 7400 nM
Estimate against measurement, compound 4: 1.2-fold (0.09 log units) below, and the stated range covers the measured number.
By their numbers in this assay, from the lowest: compounds 1, 3, 4 and 2 (each within the scatter of the next, the first and the last beyond it).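

In this assay, the acetamido group places a hydrogen-bond donor and acceptor at this aromatic carbon for the first time among these compounds, and it has four heavy atoms where chloro has one, yet the data show a 1.6-fold higher number from compound 3 to compound 4 (0.22 log units; within the scatter) and a 1.1-fold lower number from compound 2 to compound 4 (0.04 log units; within the scatter). The acetamido compound therefore falls in the same band as the halogen compounds, and the separation from the trifluoromethyl compound recurs, with a 2.3-fold higher number from compound 1 to compound 4 (0.36 log units; beyond the scatter) alongside a 2.5-fold higher number from compound 1 to compound 2 (0.40 log units; beyond the scatter); compound 3 goes against a clean two-group split, since its steps to compound 1, compound 2 and compound 4 all lie within the scatter. Nothing available bears on why the numbers fall this way.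

Going by these compounds, it remains open whether an amine, a carboxylic acid or a methoxy group at this carbon would stay in the same band, and whether a longer acyl chain in place of the acetyl part of acetamido would change the number. The compounds shown also leave open whether the amide hydrogen matters, as no N-methylacetamido analogue is among them.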